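A cyclopentylamino group replaces the ring of compound 1

The source may hold more compounds than are shown below. What is called first, only, known or untested is meant among the compounds shown, and "the series" means these compounds.

Going by the values given here, in a physicochemical assay for solubility (a higher number here means a more soluble compound, a lower number a less soluble compound), compound 1 (`C[C@@H]1CN(c2cc(C(F)(F)F)nn2-c2ccc(S(C)(=O)=O)cn2)[C@H](C)CO1`) gives 100 ug/mL, the only actual number in this small series. Compound 2 (`C[C@@H]1CN(c2c(C#N)c(C(F)(F)F)nn2-c2ccc(S(C)(=O)=O)cn2)[C@H](C)CO1`) reads > 200 ug/mL, which is a limit of the assay and not a number. Among the compounds with values here, the one measured step is an at least 2.0-fold higher number from compound 1 to compound 2 (0.30 log units; that floor lies within the scatter), with cyano in place of hydrogen on an aromatic carbon. Compound 3 (`CS(=O)(=O)c1ccc(-n2nc(C(F)(F)F)cc2NC2CCCC2)nc1`) differs from compound 1 elsewhere: a group of 6 heavy atoms (5 carbon, 1 nitrogen; one five-membered non-aromatic ring of carbon only) in place of a group of 8 heavy atoms (6 carbon, 1 nitrogen, 1 oxygen; one six-membered non-aromatic ring with 2 hetero atoms), on an aromatic carbon. Cyclopentylamino enters next to the ring nitrogen. The step to compound 2, an at least 2.0-fold higher number from compound 1 to compound 2 (0.30 log units; that floor lies within the scatter), leaves that group in place and so gives no measure of this exchange. The expectation therefore rests on the structural change alone and stays loose, with a lower number foreseen in this assay. The expected step is a 3.3-fold lower number from compound 1 to compound 3 (0.52 log units; beyond the scatter). Compound 3 is estimated at 30 ug/mL, with an expected range from 8 ug/mL to 110 ug/mL.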

Compound 3, solubility: 25 ug/mL
Estimate against measurement, compound 3: 1.2-fold (0.08 log units) above, and the stated range covers the measured number.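

Exchanging the six-membered ring for cyclopentylamino on this aromatic carbon gives a 4.0-fold lower number from compound 1 to compound 3 (0.60 log units; beyond the scatter) in this assay, the first step shown whose size is beyond the scatter. Going by these compounds alone, the group at this place can therefore shift the read-out clearly, whereas the only earlier step, the cyano exchange, sits elsewhere on the shared core and has a floor within the scatter. The exchange alters the ring, its hetero atoms and the hydrogen-bond donors and acceptors all at once, so this single step cannot assign the drop to any one of them.

The compounds shown leave open how a piperidine ring or a hydroxyl on the cyclopentyl ring would read at this place. Compound 2 stands at a limit of the assay, so the full size of its step also stays open: the limit of > 200 ug/mL in this assay, at which 1 of the 3 values shown sits.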